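Halogen swap at the chain end of compound 3

The source may hold more compounds than are shown below. What is called first, only, known or untested is meant among the compounds shown, and "the series" means these compounds.

Within the shared core, compound 1 `O=Cc1ccc(-c2cnc(C(=O)CCCCCCc3ccccc3)o2)nc1` gives 2.2 nM in an assay for inhibition of Fatty-acid amide hydrolase 1 (Rattus norvegicus), using a Dixon plot (on this read-out higher numbers stand for weaker inhibition and lower numbers for stronger inhibition), compound 2 `CSCc1ccc(-c2cnc(C(=O)CCCCCCc3ccccc3)o2)nc1` gives 11.1 nM, and compound 3 `O=C(CCCCCCc1ccccc1)c1ncc(CCCCCBr)o1` gives 6.1 nM. Among these three numbers compound 3 stands second highest: nearest is compound 2, within the scatter, and furthest is compound 1, beyond it. The measured steps are a 5.0-fold higher number from compound 1 to compound 2 (0.70 log units; beyond the scatter), a 2.8-fold higher number from compound 1 to compound 3 (0.44 log units; beyond the scatter) and a 1.8-fold lower number from compound 2 to compound 3 (0.26 log units; within the scatter); each of them exchanges the whole substituent on the aromatic carbon. Compound 4 `O=C(CCCCCCc1ccccc1)c1ncc(CCCCCCl)o1` differs from compound 3 by chloro in place of bromo on a saturated chain carbon, five bonds along the chain from an aromatic carbon. For the measured compounds named here, no measured step exchanges one halogen for another on a saturated chain; the three steps available concern replacement of the entire group and bear on this change only loosely. The expectation for compound 4 is therefore a step of a 1.3-fold higher number from compound 3 to compound 4 (0.12 log units; within the scatter) in this assay, not beyond the scatter. Compound 4 is estimated at 8 nM in this assay, with a range from 3 nM to 25 nM.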

Compound 4, inhibition constant: 5.2 nM
For compound 4 the middle estimate is 1.5-fold (0.19 log units) above the measured one; measured number inside the range.
By their numbers in this assay, from the lowest: compound 1; then compounds 4, 3 and 2 (each within the scatter of the next, the first and the last beyond it).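

In this assay, chloro in place of bromo on a saturated chain carbon, five bonds along the chain from an aromatic carbon, gives a 1.2-fold lower number from compound 3 to compound 4 (0.07 log units; within the scatter), so this exchange, the first here to leave the rest of the group in place, shows no difference between the two halogens at the chain end. Against the pyridine-bearing compounds, the chloro chain gives a 2.1-fold lower number from compound 2 to compound 4 (0.33 log units; beyond the scatter) and a 2.4-fold higher number from compound 1 to compound 4 (0.37 log units; beyond the scatter), both beyond the scatter, though the first of these only narrowly, since the bromo chain of compound 3 lies within the scatter of compound 2. No measurement on hand accounts for these values.

Open, from the compounds shown here alone, is whether the same holds for fluoro or iodo at this chain end, or for a hydroxyl, an amine or a carboxylic acid there. Also open, going by these compounds, is how a longer chain carrying chloro or bromo would compare.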